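Swapping a propyl for a cyclopropyl on an amide

The source may hold more compounds than are shown below. What is called first, only, known or untested is meant among the compounds shown, and "the series" means these compounds.

Of the compounds shown here, three built around the same core have so far been measured in an ADME assay for permeability; on this read-out higher numbers stand for higher permeability and lower numbers for lower permeability. Compound 1, with the structure `CCCNC(=O)c1cc(C(=O)NC)nn1[C@@H](C)c1ccccc1`, gives 560 nm/s. Going by the values given here, compound 2, with the structure `CNC(=O)c1cc(C(=O)N[C@H]2[C@@H]3C[C@H](O)C[C@@H]32)n([C@@H](C)c2cccc(Cl)c2)n1`, gives 333 nm/s, a number that lies within the usual scatter of the one for compound 1, so the two cannot be told apart. Compound 3, with the structure `CNC(=O)c1cc(C(=O)N[C@H]2CC[C@H](O)CC2)c([C@@H](C)c2ccccc2Cl)o1`, gives 78 nm/s, and here the gap to compound 1 is beyond the scatter: compound 1 stands clearly above compound 3.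

Compound 4, with the structure `CNC(=O)c1cc(C(=O)NC2CC2)n([C@@H](C)c2ccccc2)n1`, has not yet been measured in this assay. It differs from compound 1 in one place: cyclopropyl in place of propyl on an amide-type nitrogen. Nothing measured speaks to this exact exchange, so no direction can be read off; the step from compound 1 to compound 4 is expected to stay within the scatter of repeated measurements, a 1.1-fold lower number from compound 1 to compound 4 (0.05 log units; within the scatter). Compound 4 is therefore estimated at 500 nm/s, between 250 nm/s and 900 nm/s, because compound 1 in this assay gives 560 nm/s.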

Compound 4, apparent permeability: > 400 nm/s
Compound 4 was reported as a limit; the forecaster's own chance of this, stated with the estimate: 5%; the middle value does not contradict the limit.
By their numbers in this assay, from the lowest: compound 3; then compounds 2 and 1 (each within the scatter of the next).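

In this assay compound 4 gives > 400 nm/s as a limit of the assay and not a number. Going by these compounds alone, no step from compound 1 to compound 4 can be read from it. As far as these compounds go, whether cyclopropyl in place of propyl on an amide-type nitrogen changes the read-out at all stays open.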